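The source may hold more compounds than are shown below. What is called first, only, known or untested is meant among the compounds shown, and "the series" means these compounds.

Measured so far in a functional assay on brain (Rattus norvegicus, strain Wistar) for inhibition; a lower number here means a stronger inhibitor, a higher number a weaker inhibitor
- compound 1 `CCCCc1ccc(-c2c(C)[nH]c(=O)n2C2CCCCC2)cc1`: 27100 nM
- compound 2 `Cc1[nH]c(=O)n(C2CCCCC2)c1-c1ccc(OC(C)C)cc1`: 13000 nM
- compound 3 `Cc1[nH]c(=O)n(C2CCCCC2)c1-c1ccc(C2CCCCC2)cc1`: 28900 nM

Compound 3 shares the upper end of these numbers with compound 1 (a 1.1-fold higher number from compound 1 to compound 3 (0.03 log units; within the scatter)), and only compound 2 stands apart (a 2.2-fold higher number from compound 2 to compound 3 (0.35 log units; beyond the scatter)). Compound 4 `CCCCCCCc1ccc(-c2c(C)[nH]c(=O)n2C2CCCCC2)cc1` carries heptyl in place of cyclohexyl on an aromatic carbon. The nearest measured precedent is the exchange between butyl and cyclohexyl in the step above, which stayed within the scatter. The larger step involved isopropoxy (a 2.1-fold lower number from compound 1 to compound 2 (0.32 log units; beyond the scatter)), a group absent here. No chain longer than butyl has been measured, so this reading is uncertain. The expected change is none beyond the scatter (a 1.1-fold lower number from compound 3 to compound 4 (0.05 log units; within the scatter)). For compound 4 the estimate is 26000 nM with an expected range of 11000 nM to 60000 nM.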

Compound 4, half-maximal inhibitory concentration: 8700 nM
Beside the measured number, compound 4's estimate is 3.0-fold (0.48 log units) above it; measured number below the stated range.
By their numbers in this assay, from the lowest: compounds 4 and 2 (each within the scatter of the next); then compounds 1 and 3 (each within the scatter of the next).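

In this assay, the position on an aromatic carbon para to a large group proves sensitive to chain length: propyl added to the end of butyl gives a 3.1-fold lower number from compound 1 to compound 4 (0.49 log units; beyond the scatter), and heptyl in place of cyclohexyl gives a 3.3-fold lower number from compound 3 to compound 4 (0.52 log units; beyond the scatter), although butyl and cyclohexyl did not separate. Heptyl in place of isopropoxy gives a 1.5-fold lower number from compound 2 to compound 4 (0.17 log units; within the scatter), so these two groups remain unseparated. No available evidence bears on what underlies these steps. From the compounds shown here alone, whether pentyl and hexyl give intermediate numbers remains open. So does whether a longer chain such as decyl goes further.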